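Methylsulfonyl for Chloro: Cytotoxicity Expected to Stay Unreadable

The source may report more compounds than this note shows. Statements on the series, on what has been measured and on what is new or still open speak of the compounds shown alone.

In an ADME assay on Raji cells (Homo sapiens) for cytotoxicity, read by CellTiter-Glo and resazurin assay, with a stated time of 72 h (on this read-out higher numbers stand for an effect only at larger amounts of compound and lower numbers for an effect already at smaller amounts), compound 2 `CCOC(=O)CCCCCOc1cccc(CN(C(=O)c2ccc(-c3cccc(Cl)c3)cc2)C(C)C)c1` gives only a limit of > 18400 nM. Compound 1 `CCOC(=O)CCCCCOc1cccc(CN(C(=O)c2ccc(-c3ccc4c(c3)OCCO4)cc2)C(C)C)c1` also gives only a limit of > 24400 nM. The step that the two limits leave unreadable from compound 1 to compound 2 is therefore not readable, as both values sit at limits the limit of > 18400 nM in this assay, at which 1 of the 2 values shown sits (the limit of > 24400 nM in this assay, at which 1 of the 2 values shown sits). Compound 3 `CCOC(=O)CCCCCOc1cccc(CN(C(=O)c2ccc(-c3cccc(S(C)(=O)=O)c3)cc2)C(C)C)c1` differs from compound 2 by methylsulfonyl in place of chloro on an aromatic carbon. Going by the values given here, no measured step touches this position, so no shift beyond the scatter of this assay is expected, and compound 3 is estimated at 30000 nM, within 10000 nM to 100000 nM. The expected step is a step that the limit leaves unreadable from compound 2 to compound 3.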

Compound 3, half-maximal effective concentration: > 26000 nM
Compound 3: a limit, no number (the forecaster's own chance of this, stated with the estimate: 85%); the middle value does not contradict the limit.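

Going by these compounds alone, compound 1, compound 2 and compound 3 each give only a limit in this assay, and no step between them can be read. The compounds shown leave open at what concentration any of them acts, and whether methylsulfonyl in place of chloro changes that.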